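A few compounds are considered here, and "the series" means these few. Any claim that something is new, unique, unknown or untested is made for them only; others in the source may bear on it.

Measured so far in an assay on HeLa cells with Bile acid receptor (Homo sapiens) as the target, read by a luciferase reporter, with a stated time of 24 h; on this read-out lower numbers stand for an effect already at smaller amounts and higher numbers for an effect only at larger amounts of compound:
- compound 1 `CC(C)Oc1ccc(CNC(=O)c2ccc(C(C)(C)C)cc2)cc1`: 170 nM
- compound 2 `CC(C)(C)c1ccc(C(=O)NCc2ccc(C(=O)O)cc2F)cc1`: 7.8 nM
- compound 3 `O=C(O)c1ccc(CNC(=O)c2ccc3ccccc3c2)cc1`: 1360 nM

Compound 1 has the second highest of the three numbers in this assay: compound 3 gives a higher number, compound 2 a lower one. Compound 4 `CSc1ccc(CNC(=O)c2ccc(C(C)(C)C)cc2)cc1` is still to be measured in this assay. It differs from compound 1 in one place: methylsulfanyl in place of isopropoxy on an aromatic carbon. Going by the values given here, no pair among the measured compounds isolates this change, so the size of its effect cannot be read from the data. With both groups lacking donors and carrying one acceptor each, the step from compound 1 to compound 4 is expected to be small, around a 1.5-fold higher number from compound 1 to compound 4 (0.17 log units; within the scatter), most likely within the scatter or a modest rise. Compound 4 is therefore estimated at 250 nM, with a range from 80 nM to 800 nM.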

Compound 4, half-maximal effective concentration: 100 nM
For compound 4 the middle estimate is 2.5-fold (0.40 log units) above the measured one; the measured number falls inside the stated range.
By their numbers in this assay, from the lowest: compound 2; then compounds 4 and 1 (each within the scatter of the next); then compound 3.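

In this assay, going by these compounds alone, methylsulfanyl in place of isopropoxy on the aromatic carbon gives a 1.7-fold lower number from compound 1 to compound 4 (0.23 log units; within the scatter), the first step that isolates this position. For this one change, the position takes a group with fewer heavy atoms, and sulfur instead of oxygen, without a step beyond the scatter. Nothing available speaks to a cause for this result. Open, from the compounds shown here alone, is how a dimethylamino group or a butoxy chain would read at this position. Also open, going by these compounds, is whether this change gives a similar step on a different core.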